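The compounds below may be only part of what the source reports. "The series", "measured", "known", "first", "only" and "open" are said of these compounds alone.

Compound 1 `N=C(NCCCc1c[nH]cn1)NCCC(c1ccc(F)cc1)c1ccccn1` and compound 2 `N=C(NCCCc1c[nH]cn1)NCCC(c1ccc(F)cc1)c1cccnc1` share one core and differ only in the group carried on a saturated chain carbon bound to an aromatic carbon and a saturated chain carbon. In a functional assay on cardiac atrium for agonist activity at histamine H2 receptor (Cavia porcellus) (a lower number here means a smaller maximal response, a higher number a larger maximal response), compound 1 gives 1. In this assay compound 2 gives 1, and the step of no change at the digits printed from compound 1 to compound 2 (within the scatter) lies within the scatter, so compound 2 stands level with compound 1. Compound 3 `N=C(NCCCc1c[nH]cn1)NCCC(c1ccccc1)c1ccc(F)cc1` differs from compound 2 by phenyl in place of pyridin-3-yl on a saturated chain carbon bound to an aromatic carbon and a saturated chain carbon. Only the flat step no change at the digits printed from compound 1 to compound 2 (within the scatter) bears on this site, so no shift beyond the scatter is expected in this assay. For compound 3 the expected step is no change at the digits printed from compound 2 to compound 3 (within the scatter). Compound 3 is estimated at 1, between 0.9 and 1.05.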

Compound 3, intrinsic activity: the largest response reached, as a fraction of the reference agonist's: 1
The estimate for compound 3 equals the measured number at the digits printed, and the stated range covers the measured number.
By their numbers in this assay, from the lowest: compounds 1, 2 and 3 (each within the scatter of the next).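

In this assay, phenyl in place of pyridin-3-yl gives no change at the digits printed from compound 2 to compound 3 (within the scatter), and phenyl in place of pyridin-2-yl gives no change at the digits printed from compound 1 to compound 3 (within the scatter). At this position, a hydrogen-bond acceptor in the ring is therefore not required for the maximal response in these three compounds: the carbon-only phenyl stands level with both pyridinyl groups. No available measurement explains this flat result. Still open, as far as these compounds go, is whether an amine, a carboxylic acid or a cyclohexyl group on this saturated chain carbon would keep the maximal response level with these compounds.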